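Trifluoromethyl to cyano on compound 1

The source may report more compounds than this note shows. Statements on the series, on what has been measured and on what is new or still open speak of the compounds shown alone.

Readings so far in a functional assay on PC-3 cells (Homo sapiens) for cytotoxicity, read by MTT assay, with a stated time of 72 h; on this read-out higher numbers stand for weaker inhibition and lower numbers for stronger inhibition:
- compound 1 `CC1=C(/C=C/C(=O)/C=C/c2cccc(C(F)(F)F)c2)C(C)(C)CCC1O` gives 3500 nM
- compound 2 `CC1=C(/C=C/C(=O)/C=C/c2cc(C(F)(F)F)cc(C(F)(F)F)c2)C(C)(C)CCC1O` gives 7000 nM

Going by the values given here, compound 1 holds one of only two numbers, and the gap to its sole neighbour is a 2.0-fold higher number from compound 1 to compound 2 (0.30 log units; within the scatter), so the two values cannot be ranked. The next compound is compound 3 `CC1=C(/C=C/C(=O)/C=C/c2cccc(C#N)c2)C(C)(C)CCC1O`, which carries cyano in place of trifluoromethyl on an aromatic carbon. Among the compounds with values here, one measured step bears on this change, and only indirectly. A further trifluoromethyl in place of hydrogen on an aromatic carbon leads to compound 2 at 7000 nM, and that step stays within the scatter. Within the data shown here, no measured step involves a cyano group or the loss of a trifluoromethyl group. Among the measured compounds shown here, with that single small step as the only guide, no change beyond the scatter is expected in this assay, and no direction can be argued. The estimated step is a 1.1-fold higher number from compound 1 to compound 3 (0.06 log units; within the scatter). In this assay compound 3 is estimated at 4000 nM, with an expected range from 1400 nM to 12000 nM.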

Compound 3, half-maximal inhibitory concentration: 7200 nM
For compound 3 the middle estimate is 1.8-fold (0.26 log units) below the measured one; measured number inside the range.
By their numbers in this assay, from the lowest: compounds 1, 2 and 3 (each within the scatter of the next, the first and the last beyond it).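

Going by these compounds alone, this is the first step to lie beyond the scatter in this assay: cyano in place of trifluoromethyl on this aromatic carbon gives a modest loss (a 2.1-fold higher number from compound 1 to compound 3 (0.31 log units; beyond the scatter)), whereas the earlier step, adding a second trifluoromethyl to the ring (a 2.0-fold higher number from compound 1 to compound 2 (0.30 log units; within the scatter)), stayed within it. The earlier pair therefore could not show that the group at this place matters at all, while this pair shows that exchanging it can move the number, though only slightly past the scatter. The change replaces four heavy atoms with two and brings in a hydrogen-bond acceptor, but nothing available ties the step to either of these differences or to any other feature of the two groups.

With a single exchange at this carbon, the loss of trifluoromethyl and the entry of cyano cannot be separated, and a single small step gives no trend for the position. From the compounds shown here alone, whether the number depends on the group here remains open for the same core carrying a chlorine, a methoxy group, an amine or a carboxylic acid at this place.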